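This account rests on a few compounds, and the source may have more. Where it says the series, first, only, none or still open, it means among the compounds named here.

Of the compounds shown here, two have been measured in a functional assay on Caco-2 cells (Homo sapiens) for antiproliferative activity, read by MTT assay, with a stated time of 72 h; on this read-out lower numbers stand for stronger inhibition and higher numbers for weaker inhibition. Compound 1 `CC(=O)Oc1ccc(/C=C/C(=O)OCCSc2nc(-c3ccc(S(C)(=O)=O)cc3)n(-c3ccc(F)cc3)n2)cc1OC(C)=O` gives 12800 nM, and compound 2 `CS(=O)(=O)c1ccc(-c2nc(SCCCOC(=O)/C=C/c3ccc(O)c(O)c3)nn2-c2ccc(Br)cc2)cc1` gives 12400 nM; the two values lie within the scatter of each other, so neither can be set apart. Compound 3 `CS(=O)(=O)c1ccc(-c2nc(SCCCOC(=O)/C=C/c3ccc(O)c(O)c3)nn2-c2ccc(F)cc2)cc1` differs from compound 2 by fluoro in place of bromo on an aromatic carbon. Within the data shown here, no measured pair shows this change, so the step is expected to be small, in either direction or none beyond the scatter. Compound 3 is therefore estimated at 14000 nM in this assay, within 6000 nM to 35000 nM, a step of a 1.1-fold higher number from compound 2 to compound 3 (0.05 log units; within the scatter).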

Compound 3, half-maximal inhibitory concentration: 11200 nM
Beside the measured number, compound 3's estimate is 1.3-fold (0.10 log units) above it, and the stated range covers the measured number.
By their numbers in this assay, from the lowest: compounds 3, 2 and 1 (each within the scatter of the next).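

In this assay, among these compounds, the change from 4-bromophenyl to 4-fluorophenyl gives a 1.1-fold lower number from compound 2 to compound 3 (0.04 log units; within the scatter), the first measured step at this position. At this position, then, one halogen can stand in for the other with no difference that can be read beyond the scatter. No measured evidence bears on this result. What the compounds shown leave open is whether a group other than a halogen, such as an amine or a carboxylic acid, would give a step beyond the scatter on this aromatic carbon. Going by these compounds, whether the result would hold with a longer chain on the shared core also remains open.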